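This account rests on a few compounds, and the source may have more. Where it says the series, first, only, none or still open, it means among the compounds named here.

In a functional assay on cells (Tumor Cell line, Homo sapiens) for cytotoxicity (a higher number here means a weaker inhibitor, a lower number a stronger inhibitor), compound 1 `CN(C)Cc1cc(C(=O)/C=C/c2ccccc2Cl)cc(CN(C)C)c1O` gives 9550 nM, and compound 2 `CN(C)Cc1cc(C(=O)/C=C/c2ccc(Cl)cc2)cc(CN(C)C)c1O` gives 10000 nM. Among the compounds with values here, the only step joining the two, a 1.0-fold higher number from compound 1 to compound 2 (0.02 log units; within the scatter), lies within the scatter, so although compound 2 carries the higher of the two numbers, it is not separated from compound 1 in any meaningful way. Compound 3 `CN(C)Cc1cc(C(=O)/C=C/c2ccc(Br)cc2)cc(CN(C)C)c1O` has not yet been measured. It differs from compound 2 by bromo in place of chloro on an aromatic carbon. Within the data shown here, no measured step bears directly on this exchange: the single step available, a 1.0-fold higher number from compound 1 to compound 2 (0.02 log units; within the scatter), moved a chloro group from one place on the ring to another rather than swapping one halogen for another, and even that move stayed within the scatter. With nothing in the two numbers pointing to a shift in either direction, the step from compound 2 to compound 3 in this assay is expected to be a 1.1-fold lower number from compound 2 to compound 3 (0.02 log units; within the scatter), that is, no change beyond the scatter. Compound 3 is therefore estimated at 9500 nM in this assay, with a plausible range from 4500 nM to 20000 nM.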

Compound 3, half-maximal inhibitory concentration: 6310 nM
The estimate for compound 3 lay 1.5-fold (0.18 log units) above the measured number; low and high end bracket the measured number.
By their numbers in this assay, from the lowest: compounds 3, 1 and 2 (each within the scatter of the next).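

In this assay, within the data shown here, the exchange of chloro for bromo on an aromatic carbon, para to a large group, is the first swap of one halogen for another at this place, and it gives a 1.6-fold lower number from compound 2 to compound 3 (0.20 log units; within the scatter) with no separation of the two compounds. The wider exchange of 2-chlorophenyl for 4-bromophenyl gives a 1.5-fold lower number from compound 1 to compound 3 (0.18 log units; within the scatter) and likewise separates nothing, so the three compounds, with either of these two halogens and chloro at either of the two ring places shown, stand together in this assay. No other measurement is available that could account for these numbers. 

The compounds shown carry only chloro and bromo on this ring, so it remains open whether a fluoro group, a methoxy group, an amine or a carboxylic acid at the same place would stay within the scatter or move clearly away from it. Also open, going by these compounds, is how the number would respond to a change elsewhere, such as replacing the dimethylaminomethyl groups of the shared core with a longer chain or a different amine.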